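The compounds below may be only part of what the source reports. "The series", "measured", "known", "first", "only" and "open" are said of these compounds alone.

In an assay on membranes from Jurkat cells for displacement of a labelled ligand from Sigma intracellular receptor 2 (Homo sapiens), read by scintillation counting, with a stated time of 1 h (on this read-out lower numbers stand for stronger inhibition and higher numbers for weaker inhibition), compound 1 `Cn1nc(CN2CCCC2)nc1-c1ccc(C2CC2)cc1` gives 1000 nM, the higher of the two numbers recorded. Compound 2 `CC(C)(C)c1ccc(-c2nc(CN3CCCC3)nn2C2CC2)cc1` gives 750 nM in this assay, a gap from compound 1 that falls within the usual scatter, so the two cannot be separated. Compound 3 `Cn1nc(CN2CCCC2)nc1-c1ccc(C2(C(F)(F)F)CC2)cc1` differs from compound 1 by trifluoromethyl in place of hydrogen on a saturated ring carbon. For the measured compounds named here, no measured pair carries this change, so its effect is unknown; the step is expected to be small, not beyond the scatter, at a 1.3-fold lower number from compound 1 to compound 3 (0.10 log units; within the scatter). Compound 3 is therefore expected to give about 800 nM, within a range from 300 nM to 2500 nM.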

Compound 3, inhibition constant: > 1000 nM
Compound 3: no number, only a limit; the forecaster's own chance of this, stated with the estimate: 5%; at least 1.2-fold (0.09 log units) between middle value and limit.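

In this assay compound 3 gives > 1000 nM as a limit of the assay, not a number. Placing trifluoromethyl on this saturated ring carbon therefore gives a number no lower from compound 1 to compound 3 (the limit leaves the size open), so this change offers no sign of stronger inhibition at this position. The size of the step cannot be read because the result is only a limit: the limit of > 1000 nM in this assay, at which 1 of the 3 values shown sits. On these data alone, whether a methyl, a hydroxyl or an amine on the same ring carbon would lower the number remains open.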